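This account rests on a few compounds, and the source may have more. Where it says the series, first, only, none or still open, it means among the compounds named here.

Compound 1 `Cc1noc(C)c1-c1cnc(N)c(Oc2ccc(C(=O)NC3CC3)cc2)n1`, compound 2 `Cc1noc(C)c1-c1cnc(N)c(Oc2ccc(C(=O)NC3CCCC3)cc2)n1` and compound 3 `Cc1noc(C)c1-c1cnc(N)c(Oc2ccc(C(=O)Nc3ccccc3)cc2)n1` were measured in a functional assay on U-87MG ATCC cells for inhibition, with U-87 MG (Homo sapiens) as the target, read by MTT assay, with a stated time of 72 h; a lower number here means a stronger inhibitor, a higher number a weaker inhibitor. Compound 1 gives 43300 nM, compound 2 gives 57600 nM, and compound 3 gives 26600 nM.

Compound 3 has the lowest number of the three; its gap to compound 1 lies within the scatter, while its gap to compound 2 lies beyond it. Compound 4 `Cc1noc(C)c1-c1cnc(N)c(Oc2ccc(C(=O)Nc3cccc(Cl)n3)cc2)n1` differs from compound 3 by 6-chloropyridin-2-yl in place of phenyl on an amide-type nitrogen. The measured steps that bear on this change all alter the group on the same amide-type nitrogen: a 1.6-fold lower number from compound 1 to compound 3 (0.21 log units; within the scatter) and a 2.2-fold lower number from compound 2 to compound 3 (0.34 log units; beyond the scatter). Neither exchanges one aromatic ring for another, and both are small. Compound 4 is therefore expected to give a number close to that of compound 3, with a 1.1-fold lower number from compound 3 to compound 4 (0.03 log units; within the scatter) expected to stay within the scatter. The estimate for compound 4 is 25000 nM, in a range from 8000 nM to 70000 nM.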

Compound 4, half-maximal inhibitory concentration: 64100 nM
For compound 4 the middle estimate is 2.6-fold (0.41 log units) below the measured one; the range from low to high includes it.
By their numbers in this assay, from the lowest: compounds 3, 1, 2 and 4 (each within the scatter of the next, the first and the last beyond it).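

In this assay the group on the amide-type nitrogen proves sensitive to an exchange of one aromatic ring for another: 6-chloropyridin-2-yl in place of phenyl gives a 2.4-fold higher number from compound 3 to compound 4 (0.38 log units; beyond the scatter) as a modest step. An aromatic ring here therefore does not by itself preserve the number of compound 3. The other two steps, a 1.1-fold higher number from compound 2 to compound 4 (0.05 log units; within the scatter) and a 1.5-fold higher number from compound 1 to compound 4 (0.17 log units; within the scatter), show no separation from the non-aromatic groups.

From the compounds shown here alone, whether the ring nitrogen or the chlorine carries the step stays open: a plain pyridin-2-yl or a chlorophenyl group on this nitrogen would separate the two. No measurement at hand accounts for the step.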